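Dichlorophenyl Amide Versus a Dichloro Hydrazide Relative

This account rests on a few compounds, and the source may have more. Where it says the series, first, only, none or still open, it means among the compounds named here.

The series is anchored by compound 1, `COc1ccc(C(=O)Nc2cccc(Cl)c2Cl)cc1OC1CCCC1`. In an assay on isolated protein for inhibition of phosphodiesterase 4A (Sus scrofa) (a lower number here means a stronger inhibitor, a higher number a weaker inhibitor), compound 1 gives > 200000 nM, and this is a limit of the assay rather than a measured number (the limit of > 200000 nM in this assay, at which 1 of the 3 values shown sits). Two relatives carry a different halogenated ring on the amide-type nitrogen: compound 2, `COc1ccc(C(=O)Nc2c(F)c(F)nc(F)c2Cl)cc1OC1CCCC1`, gives 100 nM in this assay, and compound 3, `COc1ccc(C(=O)Nc2c(Cl)c(F)nc(F)c2Cl)cc1OC1CCCC1`, gives 20 nM. Within the data shown here, the single measured step joins these two: a 5.0-fold lower number from compound 2 to compound 3 (0.70 log units; beyond the scatter). Compound 4, `COc1ccc(C(=O)NN2C(Cl)=NC=CC2Cl)cc1OC1CCCC1`, has not been measured; it differs from compound 1 as follows: a group of 8 heavy atoms (4 carbon, 2 nitrogen, 2 chlorine; one six-membered non-aromatic ring with 2 hetero atoms) in place of a group of 8 heavy atoms (6 carbon, 2 chlorine; one six-membered aromatic ring of carbon only), on an amide-type nitrogen. Among the measured compounds shown here, no measured step follows an exchange of this kind, since the move from compound 2 to compound 3 alters one halogen on a ring both already share, and compound 1 itself offers only a limit. The values of compound 2 and compound 3 do show that a halogenated ring other than the dichlorophenyl can give a strong inhibitor on this core, while compound 1 with the dichlorophenyl sits at the limit. Compound 4 is therefore expected to move into the measurable range, the step of an at least 40-fold lower number from compound 1 to compound 4 (1.60 log units; beyond the scatter) being an expectation carrying wide uncertainty. Compound 4 is estimated at 5000 nM, with a range from 300 nM to 100000 nM.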

Compound 4, half-maximal inhibitory concentration: 400 nM
Beside the measured number, compound 4's estimate is 13-fold (1.10 log units) above it; measured number inside the range.
By their numbers in this assay, from the lowest: compound 3; then compound 2; then compound 4. At a limit, above all of these: compound 1.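

In this assay, exchanging the 2,3-dichlorophenyl for the group with one six-membered non-aromatic ring with 2 hetero atoms, on the amide-type nitrogen, gives an at least 500-fold lower number from compound 1 to compound 4 (2.69 log units; beyond the scatter). Among these compounds, this is the first reading of a change at this position with the rest of the molecule held constant, and it shows that this one exchange is enough to separate a compound at the limit from one with a measured value, although both groups have 8 heavy atoms, 2 of them chlorine. The step has only a lower bound, as the value of compound 1 is a limit and not a number: the limit of > 200000 nM in this assay, at which 1 of the 4 values shown sits.

The exchange alters several things at once, namely the ring nitrogens, the loss of aromaticity, the double bonds outside aromatic rings and the hydrogen-bond acceptors, so the compounds shown cannot assign the step to any one of these. They also leave open how an unsubstituted phenyl, a pyridine ring without halogens or a morpholine ring on the amide-type nitrogen would read in this assay, and whether either chlorine of the entering group is needed.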